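This account rests on a few compounds, and the source may have more. Where it says the series, first, only, none or still open, it means among the compounds named here.

Measured compounds:
- compound 1 `O=C(NC1CC1)C1CCN(c2cnccc2-c2ccccc2)CC1`, in an assay on HEK293F cells for inhibition of cholesterol 24-hydroxylase (Homo sapiens), read by trypan blue exclusion, with stated times of 15 min and 5 h (a higher number here means a weaker inhibitor, a lower number a stronger inhibitor), compound 1 gives 8.1 nM
- compound 2 `CNC(=O)C1CCN(c2cncnc2-c2ccccc2)CC1`, in this assay compound 2 gives 72 nM

Compound 2 stands at the higher of the two numbers recorded so far. Its nearest neighbour is compound 1, whose value sits well below it, beyond the scatter. Among the measured compounds shown here, the two compounds differ in several places at once, so the pair says only that compound 2 is the weaker of the two; no single change can be read from it.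

Compound 3 `CCN(C)C(=O)C1CCN(c2cncnc2-c2ccccc2)CC1` is the next member to be measured in this assay. It differs from compound 2 in one place: ethyl in place of hydrogen on an amide-type nitrogen. The change reads as methylamino to ethyl(methyl)amino, or methylcarbamoyl to ethyl(methyl)carbamoyl, and it removes a hydrogen on the amide-type nitrogen.

For the measured compounds named here, no step between measured compounds tells what this change does here. With nothing to anchor it, the expectation is a step of modest size, if any, from compound 2 to compound 3, with a slight lean toward a higher number, estimated as a 1.4-fold higher number from compound 2 to compound 3 (0.14 log units; within the scatter). Compound 3 is therefore expected to give about 100 nM in this assay, within a range of 30 nM to 330 nM.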

Compound 3, half-maximal inhibitory concentration in the cholesterol 24-hydroxylase assay: 14 nM
For compound 3 the middle estimate is 7.1-fold (0.85 log units) above the measured one; measured number outside the range, below it.
By their numbers in the cholesterol 24-hydroxylase assay, from the lowest: compounds 1 and 3 (each within the scatter of the next); then compound 2.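

Among the compounds shown here, in the cholesterol 24-hydroxylase assay, ethyl in place of hydrogen on the amide-type nitrogen gives a 5.1-fold lower number from compound 2 to compound 3 (0.71 log units; beyond the scatter), the first single-place change that can be read. On this core, the amide hydrogen is therefore not needed for inhibition, and this nitrogen accepts the added ethyl with a gain in potency. In a physicochemical assay for lipophilicity, at pH 7.4 (a lower number here means a more polar compound, a higher number a more lipophilic compound), compound 2 gives 1.4 and compound 3 gives 2.1. The change also makes the compound more lipophilic, which may account for some of the gain, although this one pair cannot separate that from the loss of the amide hydrogen: the measured distribution coefficient of compound 2, 1.4, and of compound 3, 2.1, a number 0.70 log units higher (beyond the scatter)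

On these data alone, it remains open whether a longer chain such as propyl on this nitrogen would extend the gain or whether there is a limit to the size tolerated here. A hydroxyl or an amine at the end of the ethyl would test whether potency follows lipophilicity or holds without it.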